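A few compounds are considered here, and "the series" means these few. Any claim that something is new, unique, unknown or untested is made for them only; others in the source may bear on it.

In a functional assay on PC-3 cells (Homo sapiens) for antiproliferative activity, read by MTT assay, with a stated time of 72 h (on this read-out higher numbers stand for weaker inhibition and lower numbers for stronger inhibition), compound 1 `O=C(COc1ccc(C(=O)/C=C/c2cccc(Br)c2)cc1)N[C@H]1CCOC1=O` gives 7890 nM, the lower of the two numbers in this small set. Compound 3 `O=C1OCC[C@@H]1NC(=S)SCCOc1ccc([N+](=O)[O-])cc1` gives 32500 nM in this assay, a higher number that lies beyond the usual scatter of repeated measurements. Compound 2 `O=C(CNc1ccccc1Cl)N[C@H]1CCOC1=O` reaches only a limit of this assay, > 64000 nM, and no number stands for it (the limit of > 64000 nM in this assay, at which 1 of the 3 values shown sits). Compound 4 `O=C(COc1ccc(C(=O)/C=C/c2ccc(Cl)cc2Cl)cc1)N[C@H]1CCOC1=O` is compound 1 with a single change: 2,4-dichlorophenyl in place of 3-bromophenyl on a double-bonded chain carbon bound to a double-bonded chain carbon. Among the compounds with values here, no pair of measured compounds here differs in this one place, so no measured step tells what such a change does. The step from compound 1 to compound 4 is expected to be a 1.1-fold lower number from compound 1 to compound 4 (0.05 log units; within the scatter), within the scatter. Compound 4 is therefore estimated at 7000 nM, likely between 2500 nM and 20000 nM.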

Compound 4, half-maximal inhibitory concentration: 8040 nM
Estimate against measurement, compound 4: 1.1-fold (0.06 log units) below; measured number inside the range.
By their numbers in this assay, from the lowest: compounds 1 and 4 (each within the scatter of the next); then compound 3. At a limit, above all of these: compound 2.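

In this assay, exchanging 3-bromophenyl for 2,4-dichlorophenyl gives a 1.0-fold higher number from compound 1 to compound 4 (0.01 log units; within the scatter). This first measured step at this place shows that one halogen-bearing phenyl can stand in for another there without a shift beyond the scatter. Nothing measured here explains why these two groups read alike. Going by these compounds, whether a plain phenyl would read the same stays open, and so does what an amine or a carboxylic acid would do in this place.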